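Bromo to iodo in a urea series

This account rests on a few compounds, and the source may have more. Where it says the series, first, only, none or still open, it means among the compounds named here.

Three ureas were tested in an ADME assay on the whole organism with Oryza sativa as the target, tested at 1 uM; a higher number here means a weaker effect of the compound at the concentration tested, a lower number a stronger effect. Compound 1 `C[C@H](NC(=O)Nc1ccccc1Br)c1ccccc1` gives 99%. Compound 3 `C[C@H](NC(=O)Nc1ccccc1I)c1ccccc1` differs from it by iodo in place of bromo on an aromatic carbon, and a number 1 percentage points higher from compound 1 to compound 3 (within the scatter). Compound 2 `C[C@@H](NC(=O)Nc1cccc(Br)c1)c1ccccc1` has the same atoms as compound 1, joined differently; the difference between the two cores is not broken down here. In this assay compound 2 gives 100%, level at the digits printed with compound 3 at 100% and within the scatter of compound 1. Compound 4 `C[C@@H](NC(=O)Nc1cccc(I)c1)c1ccccc1` has not yet been measured; it differs from compound 2 by iodo in place of bromo on an aromatic carbon. This is the same kind of change as that from compound 1 to compound 3, but there the iodo stands ortho to a large group, while in compound 4 it stands meta to a large group. Because a number 1 percentage points higher from compound 1 to compound 3 (within the scatter), the step from compound 2 to compound 4 is expected to be no change at the digits printed from compound 2 to compound 4 (within the scatter). Compound 4 is therefore estimated at 100%, with a likely range from 94% to 100%.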

Compound 4, a percentage reported as activity, at one concentration (the size of the read-out at that concentration, not a potency): 75%
Compound 4: the middle estimate sits 25 percentage points above what was measured, and the stated range ends above it.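

In this assay, iodo in place of bromo on an aromatic carbon gives a number 25 percentage points lower from compound 2 to compound 4 (beyond the scatter), a stronger effect at the concentration tested on the core of compound 2. Set beside the earlier step, this shows that the same change does not carry over unchanged from one core to the other in this series: the same change on two cores in this assay, a number 1 percentage points higher (within the scatter) from compound 1 to compound 3 and a number 25 percentage points lower (beyond the scatter) from compound 2 to compound 4, 26 percentage points apart, beyond the scatter of two such steps

Among the compounds shown here, it does not show which difference between the two cores matters, and with only two pairs it gives no rule for how the change will behave on any further core.

The compounds shown leave open whether the step on the core of compound 2 is particular to iodo, since only bromo and iodo appear at that place. They also leave open how a chloro, a methyl or a methoxy group on the same aromatic carbon would read in this assay, and whether such groups would follow compound 4 or compound 2.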